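The source may report more compounds than this note shows. Statements on the series, on what has been measured and on what is new or still open speak of the compounds shown alone.

Measured in an ADME assay for permeability; on this read-out higher numbers stand for higher permeability and lower numbers for lower permeability:
- compound 1 `CNC(=O)c1cc(C(=O)N[C@H]2[C@@H]3C[C@@H](OC)C[C@@H]32)n([C@@H](C)c2ccccc2)n1`: 440 nm/s
- compound 2 `CNC(=O)c1cc(C(=O)NC2CC2)n(Cc2ccccc2)n1`: > 80 nm/s, a limit of the assay and not a number
- compound 3 `CNC(=O)c1cc(C(=O)N[C@H]2CC[C@H](O)CC2)c([C@@H](C)c2cccc(OC)c2)o1`: 44 nm/s

Among the two actual numbers, compound 1 stands highest at 440 nm/s. Compound 3 lies lower at 44 nm/s, a gap beyond the scatter. Compound 2 gives only a limit: the limit of > 80 nm/s in this assay, at which 1 of the 3 values shown sits.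

The next step leads to compound 4 `CNC(=O)c1cc(C(=O)NCCO)n([C@@H](C)c2ccccc2)n1`, which keeps the core of compound 1 and changes only the group on the amide-type nitrogen: a group of 3 heavy atoms (2 carbon, 1 oxygen; no ring) in place of a group of 8 heavy atoms (7 carbon, 1 oxygen; one three-membered non-aromatic ring of carbon only, one five-membered non-aromatic ring of carbon only), on an amide-type nitrogen. Among the compounds with values here, no step between measured compounds isolates this change, so the expectation rests on thin evidence. The closest guide is compound 3, whose group on the amide-type nitrogen also carries a hydroxyl and which reads 44 nm/s, although it differs from compound 1 elsewhere too. The expected step in this assay is a 4.0-fold lower number from compound 1 to compound 4 (0.60 log units; beyond the scatter), downward and beyond the scatter. For compound 4 the estimated value is 110 nm/s. Compound 4 is expected to fall between 35 nm/s and 300 nm/s.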

Compound 4, apparent permeability: 59 nm/s
Estimate against measurement, compound 4: 1.9-fold (0.27 log units) above; the range from low to high includes it.
By their numbers in this assay, from the lowest: compounds 3 and 4 (each within the scatter of the next); then compound 1.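

Placing 2-hydroxyethyl on the amide-type nitrogen, in place of the group with a three-membered and a five-membered carbon ring, gives a 7.5-fold lower number from compound 1 to compound 4 (0.87 log units; beyond the scatter) in this assay. Within the data shown here, this is the first reading of a single change on the core of compound 1, and it shows that the read-out responds to the group at this place, which the earlier compounds, differing from one another in more than one place, could not show. No measurement shown here bears on why the number falls, or on whether the hydrogen-bond donor, the smaller size or the loss of the rings carries the step.

An ethyl or 2-methoxyethyl group at this place, with no hydroxyl, would separate the hydroxyl from the size of the group. From the compounds shown here alone, a longer chain such as 3-hydroxypropyl, or a chain ending in an amine, remains open on the same core.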